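The source may hold more compounds than are shown below. What is called first, only, known or untested is meant among the compounds shown, and "the series" means these compounds.

Working notes on the series.

Going by the values given here, compound 2 `COc1ccc(C(=O)c2ccc([N+](=O)[O-])cc2)cc1OCC(=O)OC[C@@H]1C=C[C@H](n2cc(C)c(=O)[nH]c2=O)O1` gives 50200 nM in a functional assay on HeLa cells (Homo sapiens) for antiproliferative activity, read by MTT assay, with a stated time of 48 h (on this read-out higher numbers stand for weaker inhibition and lower numbers for stronger inhibition), the higher of the two numbers so far; compound 1 `COc1ccc(C(=O)c2ccccc2OC)cc1OCC(=O)OC[C@@H]1C=C[C@H](n2cc(C)c(=O)[nH]c2=O)O1` gives 30200 nM in this assay, and the step of a 1.7-fold higher number from compound 1 to compound 2 (0.22 log units; within the scatter) lies within the scatter, so the two values are not ordered.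

Compound 3 `COc1ccc(C(=O)c2ccccc2Cl)cc1OCC(=O)OC[C@@H]1C=C[C@H](n2cc(C)c(=O)[nH]c2=O)O1` is not yet measured. It differs from compound 2 by 2-chlorophenyl in place of 4-nitrophenyl on a carbonyl carbon. Among the compounds with values here, the only step that bears on this change is the earlier swap of the aryl group on the same carbonyl carbon, a 1.7-fold higher number from compound 1 to compound 2 (0.22 log units; within the scatter), which stayed within the scatter. Within the data shown here, no other step on this position is available, and compound 1 carries neither of the two groups exchanged here. On that basis, no step beyond the scatter is expected from compound 2 to compound 3, and the expected step of a 1.4-fold lower number from compound 2 to compound 3 (0.16 log units; within the scatter) is set close to nothing. Compound 3 is therefore estimated at 35000 nM in this assay, with an expected range from 15000 nM to 80000 nM.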

Compound 3, half-maximal inhibitory concentration: 45800 nM
The estimate for compound 3 lay 1.3-fold (0.12 log units) below the measured number, within the range that was stated.
By their numbers in this assay, from the lowest: compounds 1, 3 and 2 (each within the scatter of the next).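

In this assay, a second swap on this carbonyl carbon, 2-chlorophenyl in place of 4-nitrophenyl, also stays within the scatter (a 1.1-fold lower number from compound 2 to compound 3 (0.04 log units; within the scatter)). Going by these compounds alone, the exchange of chloro for methoxy on the aromatic carbon, read for the first time here, does the same (a 1.5-fold higher number from compound 1 to compound 3 (0.18 log units; within the scatter)), so 2-methoxyphenyl, 4-nitrophenyl and 2-chlorophenyl on this carbon give values that cannot be ordered, where the earlier pair offered only a single swap. Nothing at hand accounts for this lack of separation.

The compounds shown leave open whether an aminophenyl group, a carboxyphenyl group or plain phenyl on this carbonyl carbon would give a step beyond the scatter. Also open, on these data alone, is whether 4-chlorophenyl would read the same as 2-chlorophenyl.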